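Working notes: from compound 3 to compound 4

The source may report more compounds than this note shows. Statements on the series, on what has been measured and on what is new or still open speak of the compounds shown alone.

Measured in a functional assay on MCF7 cells (Homo sapiens) for inhibition, read by sulforhodamine B assay (on this read-out lower numbers stand for stronger inhibition and higher numbers for weaker inhibition), so far:
- compound 1 `O=C1C(N2CCCC2)=CC(=O)c2c1nc1n2[C@H]2OC[C@@H](O)[C@H]2OC1` gives > 16000 nM as a limit
- compound 2 `O=C1C(NC2CC2)=CC(=O)c2c1nc1n2[C@H]2OC[C@@H](O)[C@H]2OC1` gives > 16000 nM as a limit
- compound 3 `O=C1C(NC2CCCCC2)=CC(=O)c2c1nc1n2[C@H]2OC[C@@H](O)[C@H]2OC1` gives > 16000 nM as a limit

Compound 3 stands at the limit > 16000 nM and has no number of its own. All three compounds share one reading (the limit of > 16000 nM in this assay, at which 3 of the 3 values shown sit) so far.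

Compound 4 `CCCN(CCC)C1=CC(=O)c2c(nc3n2[C@H]2OC[C@@H](O)[C@H]2OC3)C1=O` keeps the shared core and carries dipropylamino in place of cyclohexylamino on a double-bonded ring carbon. The measured changes to the amine group are a step that the two limits leave unreadable from compound 1 to compound 2 and a step that the two limits leave unreadable from compound 1 to compound 3 and also a step that the two limits leave unreadable from compound 2 to compound 3 in this series. None of them has a readable size, so no size carries over to the new change. In this assay no step beyond the scatter is expected in either direction, and compound 4 is expected to report a limit as well. The expected step is a step that the limit leaves unreadable from compound 3 to compound 4 on this estimate. For compound 4 the estimated value is 20000 nM with an expected range from 7000 nM to 50000 nM if a number is reported at all.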

Compound 4, half-maximal inhibitory concentration: > 16000 nM
Compound 4: only a limit was reported; the forecaster's own chance of this, stated with the estimate: 80%; the middle value is on the limit's open side.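

In this assay compound 4 gives > 16000 nM as a limit and not a number, so the steps to compound 4 from compound 1, compound 2 and compound 3 cannot be read. The compounds shown leave open how these amine groups on the shared core rank against one another, because all share one reading: the limit of > 16000 nM in this assay, at which 4 of the 4 values shown sit.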